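This account rests on a few compounds, and the source may have more. Where it says the series, first, only, none or still open, it means among the compounds named here.

Compound 1 `COc1ccc(/C=C/C(=O)c2ccc(OC)c3c2OC(C)(C)C=C3)cc1OCC=C(C)C`: > 10000 nM (a limit)
Compound 2 `COc1ccc(/C=C/C(=O)c2ccc(OC)c3c2OC(C)(C)C=C3)cc1OCCO`: 8750 nM

Among the measured compounds shown here, in a functional assay on K562 cells (Homo sapiens) for cytotoxicity, read by MTT assay (a lower number here means a stronger inhibitor, a higher number a weaker inhibitor), compound 2 gives 8750 nM, the only exact number so far. Compound 1 reaches only a limit of the assay, > 10000 nM.

Compound 3 `CCC(=O)Oc1cc(/C=C/C(=O)c2ccc(OC)c3c2OC(C)(C)C=C3)ccc1OC` differs from compound 2 as follows: propanoyl in place of 2-hydroxyethyl on an oxygen on an aromatic ring. For the measured compounds named here, one measured step bears on this, because an at least 1.1-fold lower number from compound 1 to compound 2 (0.05 log units; that floor lies within the scatter) also alters the group on an oxygen on an aromatic ring. That step gives no firm size or direction, so no step beyond the scatter is expected in this assay. The expected step is a 1.1-fold lower number from compound 2 to compound 3 (0.04 log units; within the scatter). For compound 3 the estimated value is 8000 nM, with an expected range of 3000 nM to 15000 nM.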

Compound 3, half-maximal inhibitory concentration: 160 nM
For compound 3 the middle estimate is 50-fold (1.70 log units) above the measured one; the whole stated range lies above it.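

In this assay, the group on this oxygen on an aromatic ring had shown no firm effect, but propanoyl in place of 2-hydroxyethyl gives a 55-fold lower number from compound 2 to compound 3 (1.74 log units; beyond the scatter). Propanoyl in place of 3-methylbut-2-en-1-yl likewise gives an at least 62-fold lower number from compound 1 to compound 3 (1.79 log units; beyond the scatter). The value for compound 1 is only a limit, so that step is a floor: the limit of > 10000 nM in this assay, at which 1 of the 3 values shown sits.

The compounds shown cannot tell whether this gain belongs to propanoyl alone. An acetyl group, a longer acyl chain such as butanoyl, or a free hydroxyl on the same oxygen could separate these possibilities.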